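Hydroxy for Tert-Butyl: What Compound 4 Should Show

The source may report more compounds than this note shows. Statements on the series, on what has been measured and on what is new or still open speak of the compounds shown alone.

Compound 1, `O=C(N/N=C/c1ccc(O)cc1)c1ccc(O)cc1`: 18.4%
Compound 2, `CC(C)(C)c1ccc(C(=O)N/N=C/c2ccc(O)cc2)cc1`: 10.2%
Compound 3, `CC(C)(C)c1ccc(C(=O)N/N=C/c2cc(O)cc(O)c2)cc1`: 7%

Of the compounds shown here, three have so far been measured in a physicochemical assay, read by spectrophotometry, with a stated time of 60 min, tested at 35 uM; a higher number here means a stronger effect of the compound at the concentration tested, a lower number a weaker effect. Compound 3 gives the lowest of the three numbers in this assay; its nearest neighbour is compound 2, which lies within the scatter of it, while compound 1 stands beyond the scatter above it. Compound 4, `O=C(N/N=C/c1cc(O)cc(O)c1)c1ccc(O)cc1`, has not yet been measured. It differs from compound 3 in a single place: hydroxy in place of tert-butyl on an aromatic carbon.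

Within the data shown here, one measured step bears directly on this change, being the same exchange run the other way: a number 8.2 percentage points lower from compound 1 to compound 2 (within the scatter), a shift that stays within the scatter. Running that exchange in reverse on compound 3 would therefore suggest a rise of similar size, which is itself still within the scatter, so no step beyond the scatter is expected here.

Compound 4 is estimated at 15% in this assay, with a range from 5% to 26%. That estimate means a step of a number 8 percentage points higher from compound 3 to compound 4 (within the scatter) is expected from the exchange.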

Compound 4, a percentage reported as inhibition, at one concentration (the size of the read-out at that concentration, not a potency): 5.6%
For compound 4 the middle estimate is 9.4 percentage points above the measured one; the range from low to high includes it.
By their numbers in this assay, from the lowest: compounds 4, 3, 2 and 1 (each within the scatter of the next, the first and the last beyond it).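

In this assay the new result is a number 1.4 percentage points lower from compound 3 to compound 4 (within the scatter) when hydroxy takes the place of tert-butyl on an aromatic carbon, para to a large group. The earlier step of a number 8.2 percentage points lower from compound 1 to compound 2 (within the scatter) ran the same exchange in the opposite direction, so this exchange has now been read on two different partners, and neither reading leaves the scatter. At this position, then, the read-out does not separate the two groups in either setting, although tert-butyl brings four carbon atoms and no hydrogen-bond donor or acceptor, while hydroxy brings a single oxygen with one donor and one acceptor.

No measurement available here offers a reason for this result. Still open, as far as these compounds go, is whether a group of another kind at the same place, such as an amine, a carboxylic acid or a longer chain, would shift the number beyond the scatter, or whether this position stays just as unresponsive with those groups as it has with hydroxy and tert-butyl.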